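This account rests on a few compounds, and the source may have more. Where it says the series, first, only, none or still open, it means among the compounds named here.

Working notes on the series in a functional assay on MKN-45 cells (Homo sapiens) for cytotoxicity, read by MTT assay, with a stated time of 72 h; on this read-out higher numbers stand for weaker inhibition and lower numbers for stronger inhibition.

Going by the values given here, compound 1 `CN(C)CCn1cnnc1-c1cc(Oc2ccc(NC(=O)N/N=C/c3ccc(F)cc3)cc2F)ccn1` gives 1030 nM in this assay, the highest of the three numbers so far. Compound 2 `CN(C)CCn1cnnc1-c1cc(Oc2ccc(NC(=O)N/N=C/c3cccc(Br)c3)cc2F)ccn1` gives 450 nM and compound 3 `CN(C)CCn1cnnc1-c1cc(Oc2ccc(NC(=O)N/N=C/c3ccc(Cl)cc3)cc2F)ccn1` gives 570 nM. The two measured steps from compound 1 both alter the aryl group on the carbon with a double bond to nitrogen: a 2.3-fold lower number from compound 1 to compound 2 (0.36 log units; beyond the scatter), and a 1.8-fold lower number from compound 1 to compound 3 (0.26 log units; within the scatter). Between compound 2 and compound 3 the change is a 1.3-fold higher number from compound 2 to compound 3 (0.10 log units; within the scatter).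

Compound 4 `COc1cc(/C=N/NC(=O)Nc2ccc(Oc3ccnc(-c4nncn4CCN(C)C)c3)c(F)c2)ccc1O` differs from compound 1 at the same carbon: 4-hydroxy-3-methoxyphenyl in place of 4-fluorophenyl on a carbon with a double bond to nitrogen. Among the compounds with values here, the measured steps bear on it only in that they sit at the same position; none of them brings in a hydrogen-bond donor or acceptor, so no close precedent exists for the entering group. Given that every change so far at this carbon stayed modest or within the scatter, the expectation for a 1.1-fold lower number from compound 1 to compound 4 (0.06 log units; within the scatter) is a step that does not clearly leave the scatter, with a wide range allowed. Compound 4 is estimated at 900 nM in this assay, with a range from 300 nM to 2700 nM.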

Compound 4, half-maximal inhibitory concentration: 3780 nM
The estimate for compound 4 lay 4.2-fold (0.62 log units) below the measured number; the whole stated range lies below it.
By their numbers in this assay, from the lowest: compounds 2, 3 and 1 (each within the scatter of the next, the first and the last beyond it); then compound 4.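

In this assay the carbon with a double bond to nitrogen proves sensitive to the choice of aryl group: the 4-hydroxy-3-methoxyphenyl group gives a 3.7-fold higher number from compound 1 to compound 4 (0.56 log units; beyond the scatter) and a 6.6-fold higher number from compound 3 to compound 4 (0.82 log units; beyond the scatter) and also an 8.4-fold higher number from compound 2 to compound 4 (0.92 log units; beyond the scatter) as the steps from the three earlier compounds. Going by these compounds alone, all three lie beyond the scatter, which makes compound 4 the weakest of the four here, whereas the earlier steps at this carbon stayed modest or within the scatter. The entering group also brings a hydrogen-bond donor and hydrogen-bond acceptors where 4-fluorophenyl has none, but nothing shown accounts for the rise.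

As far as these compounds go, the hydroxy and methoxy groups enter together, so their separate contributions stay open. Also open, from the compounds shown here alone, is how an amine or a carboxylic acid on the phenyl ring would behave at this carbon.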